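The compounds below may be only part of what the source reports. "The series", "measured", "known", "first", "only" and "open" are said of these compounds alone.

Two compounds from this series have been examined in an assay on isolated protein for inhibition of Myc proto-oncogene protein (Homo sapiens), read by mobility shift assay, tested at 100 uM; a lower number here means less inhibition, a higher number more inhibition at the concentration tested (going by the name of the read-out). Compound 1, `O=[N+]([O-])c1ccc(N2CCCCC2)c2nonc12`, gives 10% in this assay. Compound 2, `Cc1ccccc1Nc1ccc([N+](=O)[O-])c2nonc12`, gives 11% in this assay. Of the two numbers, compound 2 shows the higher one, yet compound 1 lies only a single percentage point away, a gap that falls within the scatter of repeated measurements, so the two compounds cannot be told apart on these data.

Compound 3, `COc1ccccc1Nc1ccc([N+](=O)[O-])c2nonc12`, has not yet been measured. It differs from compound 2 in one place: methoxy in place of methyl on an aromatic carbon. Among the compounds with values here, no pair of measured compounds in this set shows what such a change does in this assay, so there is no measured step to lean on. Given that compound 1 and compound 2 sit at the same level, the step from compound 2 to compound 3 is expected to be a number 1 percentage points lower from compound 2 to compound 3 (within the scatter), that is, none beyond the scatter. Compound 3 is therefore estimated to give 10% in this assay, with a range from 0% to 25%.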

Compound 3, a percentage reported as inhibition, at one concentration (the size of the read-out at that concentration, not a potency): 0%
Beside the measured number, compound 3's estimate is 10 percentage points above it; the measured number falls inside the stated range.
By their numbers in this assay, from the lowest: compounds 3, 1 and 2 (each within the scatter of the next, the first and the last beyond it).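

In this assay, within the data shown here, the exchange of methyl for methoxy on an aromatic carbon, ortho to a large group, gives a number 11 percentage points lower from compound 2 to compound 3 (beyond the scatter), the first step that can be read. This shows that the group at this position is not indifferent to the read-out: adding the methoxy oxygen is enough to produce a step beyond the scatter, even though the numbers are all small at the single concentration tested. Nothing among the data shown accounts for this step.

As far as these compounds go, whether a hydroxyl, an ethoxy or an amine at this same position would also lower the number remains open. So does whether methoxy in place of methyl would have a similar effect elsewhere on the same six-membered ring.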